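The compounds below may be only part of what the source reports. "The series", "measured", "known", "first", "only" and "open" are said of these compounds alone.

Measured so far, with potency in a functional assay on A549 cells (Homo sapiens) for antiproliferative activity, read by MTT assay, with a stated time of 72 h; a higher number here means a weaker inhibitor, a lower number a stronger inhibitor:
compound 1, `CC(C)(C)c1ccc(OCCCON2C(N)=NC(N)=NC23CCSCC3)cc1`: 1 nM
compound 2, `NC1=NC2(CCSCC2)N(OCCCOc2ccc(Br)cc2)C(N)=N1`: 740 nM
compound 3, `NC1=NC2(CCOCC2)N(OCCCOc2ccc(Br)cc2)C(N)=N1`: 280 nM

Compound 2 and compound 1 share a core and differ in one place: tert-butyl in place of bromo on an aromatic carbon. That single change gave a 740-fold lower number from compound 2 to compound 1 (2.87 log units; beyond the scatter). Compound 3 carries the same bromo-bearing side chain as compound 2 on a different core; the difference between the two cores is not broken down here. In this assay compound 3 gives 280 nM, which stands nearer to compound 2 than to compound 1.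

Compound 4, `CC(C)(C)c1ccc(OCCCON2C(N)=NC(N)=NC23CCOCC3)cc1`, is the counterpart of compound 1 on the core of compound 3. It differs from compound 3 in one place: tert-butyl in place of bromo on an aromatic carbon. Going by the values given here, this is the same change as the one from compound 2 to compound 1, made at the same kind of place. Among the compounds shown the change occurs twice in all, and only one of the two instances has been measured, so the expectation for compound 4 rests on a single step. That step was large and beyond the scatter, and a step of similar size is expected here. The expected step from compound 3 to compound 4 in this assay is a 470-fold lower number from compound 3 to compound 4 (2.67 log units; beyond the scatter), resting on compound 2 and compound 1 having given a 740-fold lower number from compound 2 to compound 1 (2.87 log units; beyond the scatter). Compound 4 is accordingly expected to give about 0.6 nM, most likely between 0.1 nM and 5 nM. Whether the core difference that separates compound 3 from compound 2 carries over once tert-butyl is in place cannot be told from one core pair.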

Compound 4, half-maximal inhibitory concentration: 500 nM
Compound 4: middle estimate off by 830-fold (2.92 log units), on the low side, outside the stated range (above it).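

In this assay, tert-butyl in place of bromo on an aromatic carbon gives a 1.8-fold higher number from compound 3 to compound 4 (0.25 log units; within the scatter), so on this core the two groups cannot be told apart, whereas on the core of compound 1 they lie far apart. The change therefore does not carry over from one of these cores to the other: the same change on two cores in this assay, a 740-fold lower number (2.87 log units; beyond the scatter) from compound 2 to compound 1 and a 1.8-fold higher number (0.25 log units; within the scatter) from compound 3 to compound 4, 1300-fold (3.12 log units) apart, beyond the scatter of two such steps For this pair of cores, the step measured on one gave no guide to the step on the other, but this does not show what in the cores accounts for the gap, and two core pairs support no rule for the wider series.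

Going by these compounds, it remains open whether the low number of compound 1, at 1 nM, is particular to tert-butyl on that core or is shared by other groups at the same place, such as isopropyl, chloro or trifluoromethyl. Also open, on these data alone, is whether the same split between the two cores appears with a longer chain linking the aromatic ring to the core.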